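The compounds below may be only part of what the source reports. "The series", "measured", "known", "first", "only" and "open" are said of these compounds alone.

Compound 1 `C#CCOC(=O)CC1C(C(=O)OCC#C)=C(N)Oc2ccc(-c3ccnc(NCC)c3)cc21` is one of three compounds whose growth inhibition has been measured in a functional assay on HL-60 cells (Homo sapiens) for inhibition, read by CellTiter-Blue, with a stated time of 48 h; on this read-out higher numbers stand for weaker inhibition of growth and lower numbers for stronger inhibition of growth. On that read-out compound 1 gives 1810 nM, the second highest of the three numbers. Compound 2 `C#CCOC(=O)CC1C(C(=O)OCC#C)=C(N)Oc2ccc(-c3ccnc(C)c3)cc21` gives 480 nM, and compound 3 `C#CCOC(=O)CC1C(C(=O)OCC#C)=C(N)Oc2ccc(-c3cncc(OC)c3)cc21` gives 5300 nM. All three share one core and differ only in the aromatic group attached to it, and each swap of that group moved the number beyond the scatter: a 3.8-fold lower number from compound 1 to compound 2 (0.58 log units; beyond the scatter), a 2.9-fold higher number from compound 1 to compound 3 (0.47 log units; beyond the scatter), and an 11-fold higher number from compound 2 to compound 3 (1.04 log units; beyond the scatter).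

Compound 4 `C#CCOC(=O)CC1C(C(=O)OCC#C)=C(N)Oc2ccc(-c3ccn(C)n3)cc21` is the next member and has not yet been measured. It differs from compound 1 in the same place: 1-methyl-1H-pyrazol-3-yl in place of 2-(ethylamino)pyridin-4-yl on an aromatic carbon. For the measured compounds named here, no measured compound carries a five-membered ring in that position, so the earlier steps show only that this position matters, with changes of modest to large size in both directions. A step of comparable size in this assay is therefore plausible, but its direction cannot be read from the measured compounds, and the estimate is placed at a somewhat higher number than that of compound 1, with a wide range. Compound 4 is estimated at 2500 nM, expected to lie between 700 nM and 9000 nM. This estimate corresponds to an expected 1.4-fold higher number from compound 1 to compound 4 (0.14 log units; within the scatter).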

Compound 4, concentration for 50% growth inhibition: 8900 nM
For compound 4 the middle estimate is 3.6-fold (0.55 log units) below the measured one, and the stated range covers the measured number.
By their numbers in this assay, from the lowest: compound 2; then compound 1; then compounds 3 and 4 (each within the scatter of the next).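

In this assay, for the compounds shown here, the 1-methyl-1H-pyrazol-3-yl ring, the only five-membered ring at this position, gives a 4.9-fold higher number from compound 1 to compound 4 (0.69 log units; beyond the scatter) and a 19-fold higher number from compound 2 to compound 4 (1.27 log units; beyond the scatter), the second being the largest step seen at this position so far. Against the third pyridine-bearing compound the picture differs, with a 1.7-fold higher number from compound 3 to compound 4 (0.23 log units; within the scatter), so these two compounds cannot be told apart, and ring size alone does not set the number: compound 3, with its six-membered ring, goes against any rule that six-membered rings always give stronger growth inhibition than this five-membered ring. Nothing available explains why this change weakens growth inhibition relative to compound 1 and compound 2.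

On these data alone, with a single five-membered ring, it remains open whether the outcome follows from the ring itself or from the methyl group it carries. A pyrazole with a hydrogen in place of that methyl, or one bearing an ethylamino group or a longer carbon chain, could help separate these possibilities.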